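This account rests on a few compounds, and the source may have more. Where it says the series, first, only, none or still open, it means among the compounds named here.

The measured compounds:
Compound 1, `COC(=O)N1[C@@H]2C=C[C@@](OC)(C(=O)c3c2cc(OC)c(OC)c3OCc2ccccc2)N1C(=O)OC`, gives in an ADME assay on KB cells (Homo sapiens) for cytotoxicity (on this read-out higher numbers stand for an effect only at larger amounts of compound and lower numbers for an effect already at smaller amounts), a limit of > 300 ug/mL.
Compound 2, `COc1cc2c(c(OC)c1OC)C(=O)[C@]1(OC)C=C[C@H]2N(C(=O)OCC(C)C)N1C(=O)OCC(C)C`, gives in this assay a limit of > 300 ug/mL.
Compound 3, `COc1ccc(COc2c(OC)c(OC)cc3c2C(=O)[C@]2(OC)C=C[C@H]3N(C(=O)OCC(C)C)N2C(=O)OCC(C)C)cc1`, gives in this assay 47.9 ug/mL.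

Compound 1 therefore stands at the limit of > 300 ug/mL in this assay, at which 2 of the 3 values shown sit, so only a lower bound is known for it. Compound 4 is `COC(=O)N1[C@@H]2C=C[C@@](OC)(C(=O)c3c2cc(OC)c(OC)c3OCc2ccc(Cl)cc2)N1C(=O)OC`, and the change from compound 1 is chloro in place of hydrogen on an aromatic carbon. For the measured compounds named here, the only measured step, an at least 6.2-fold lower number from compound 2 to compound 3 (0.79 log units; beyond the scatter), places a 4-methoxyphenyl on the saturated carbon of the benzyloxy group rather than on its aromatic ring, so it bears on this change only loosely. A small lowering or none beyond the scatter is expected. Compound 4 is estimated at 200 ug/mL, between 60 ug/mL and 300 ug/mL. The estimate means an expected step of an at least 1.5-fold lower number from compound 1 to compound 4 (0.17 log units; that floor lies within the scatter).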

Compound 4, concentration for half-maximal effect: 55.9 ug/mL
Compound 4: the middle estimate sits 3.6-fold (0.55 log units) above what was measured; measured number outside the range, below it.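

For the compounds shown here, putting chloro in place of hydrogen on the aromatic ring of the benzyloxy group gives an at least 5.3-fold lower number from compound 1 to compound 4 (0.72 log units; beyond the scatter) in this assay, so this ring position, which no earlier step touched, clearly affects the read-out. For compound 1 only a limit is known, so the true size of the step remains unknown: the limit of > 300 ug/mL in this assay, at which 2 of the 4 values shown sit.

On these data alone, whether an amine or a carboxylic acid at the same place would act like chloro remains open. So does whether chloro at other places on this ring would give a similar step.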